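Aryl amide swap on the piperidine series, compound 3

The compounds below may be only part of what the source reports. "The series", "measured", "known", "first", "only" and "open" are said of these compounds alone.

Measured so far in a functional assay on HEK293 cells for agonist activity at D(4) dopamine receptor (Homo sapiens), read by FLIPR; a higher number here means a larger maximal response, a lower number a smaller maximal response:
compound 1 `Cc1cccc(NC(=O)CN2CCC(c3cccc(C#N)n3)CC2)c1` gives 42%
compound 2 `C=Cc1cccc(C(=O)NCN2CCC(c3cccc[n+]3[O-])CC2)c1` gives 63%

Compound 2 stands highest of the two numbers; the nearest, compound 1, lies lower by a margin beyond the usual scatter. The two compounds differ at more than one place, so no single change can be read from that pair.

Compound 3 `O=C(NCN1CCC(c2cccc[n+]2[O-])CC1)c1cnccc1Cl` is not yet measured. It differs from compound 2 by 4-chloropyridin-3-yl in place of 3-vinylphenyl on a carbonyl carbon. Among the compounds with values here, no measured pair carries this change alone, so its size is not known from the series. With nothing to show that the aryl group on the carbonyl carbon drives the response, a step of a number 8 percentage points lower from compound 2 to compound 3 (within the scatter) is expected, small and downward, or none beyond the scatter. Compound 3 is estimated at 55%, with a range from 35% to 75%.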

Compound 3, largest response reached (reported as efficacy), in percent of the reference or control that the assay uses: 44%
The estimate for compound 3 lay 11 percentage points above the measured number; the measured number falls inside the stated range.
By their numbers in this assay, from the lowest: compounds 1 and 3 (each within the scatter of the next); then compound 2.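

Within the data shown here, the aryl group on the carbonyl carbon is not a silent position: in this assay, 4-chloropyridin-3-yl in place of 3-vinylphenyl gives a number 19 percentage points lower from compound 2 to compound 3 (beyond the scatter) and is the first change that can be read alone. With the rest of the structure unchanged, the maximal response therefore depends on this aryl group, although a single pair sets no trend. Nothing available bears on why the response moves with this change.

The compounds shown leave open which part of the change carries the step, as the vinyl group leaves while the ring nitrogen and the chlorine enter together. Plain phenyl, 3-chlorophenyl or pyridin-3-yl on the carbonyl carbon would separate these parts.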